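A Bromophenyl Swap and the Cytotoxicity Read-Out

This account rests on a few compounds, and the source may have more. Where it says the series, first, only, none or still open, it means among the compounds named here.

Within the data shown here, in an ADME assay on MT4 cells (Homo sapiens) for cytotoxicity, read by MTT assay, with a stated time of 5 days (on this read-out lower numbers stand for higher toxicity in this test and higher numbers for lower toxicity in this test), compound 2 (`Cc1cc(OCC(=O)Nc2ccc(Br)cc2)nc(Nc2ccc(C#N)cc2)n1`) gives 930 nM as the only true number so far. Compound 1 (`N#Cc1ccc(Nc2nccc(OCC(=O)Nc3ccc(C#N)cc3F)n2)cc1`) shows > 321000 nM in the same test, and this value is a limit and not a number.

Compound 3 (`Cc1cc(OCC(=O)Nc2ccc(C#N)cc2F)nc(Nc2ccc(C#N)cc2)n1`) has not yet been measured. The change from compound 2 is 4-cyano-2-fluorophenyl in place of 4-bromophenyl on an amide-type nitrogen and it puts 4-cyano-2-fluorophenyl in place of 4-bromophenyl on an amide-type nitrogen, leaving the rest of the structure untouched. Compound 1 carries that same 4-cyano-2-fluorophenyl, though it differs from compound 3 elsewhere, so it offers only a rough guide. With that caution, a rise well beyond the scatter is expected, pointing to lower toxicity in this assay and amounting to an estimated 16-fold higher number from compound 2 to compound 3 (1.21 log units; beyond the scatter) in size. For compound 3 the estimated value is 15000 nM with 1500 nM to 150000 nM as the expected range.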

Compound 3, half-maximal cytotoxic concentration: > 310000 nM
Compound 3 gave a limit, no number (the forecaster's own chance of this, stated with the estimate: 30%); at least 20-fold (1.31 log units) between middle value and limit.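

In this assay, 4-cyano-2-fluorophenyl in place of 4-bromophenyl on an amide-type nitrogen gives an at least 330-fold higher number from compound 2 to compound 3 (2.52 log units; beyond the scatter), which points to lower toxicity in this test. Among these compounds, this is the first comparison here in which only this one place changes, so the effect no longer has to be judged from compound 1, which also differs elsewhere. Going by these compounds, compound 3 gives > 310000 nM, which is a limit and not a number, so the full size of the step remains unknown, and the step from compound 1 to compound 3 cannot be read.

On these data alone, the nitrile and the fluorine enter together, so the share of each in the rise stays open. As far as these compounds go, whether 4-cyanophenyl or 4-chlorophenyl at this place would sit nearer compound 2 or compound 3 also stays open.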